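A few compounds are considered here, and "the series" means these few. Any claim that something is new, unique, unknown or untested is made for them only; others in the source may bear on it.

Of the compounds shown here, three built on one shared core have been tested in a functional assay on SW480 cells (Homo sapiens) for cytotoxicity, read by MTT assay, with a stated time of 4 days (on this read-out lower numbers stand for stronger inhibition and higher numbers for weaker inhibition), and not one of them has yielded a number. Compound 1 `C=C1C[C@]23C[C@@]1(O)CC[C@H]2c1ccc(OS(=O)(=O)c2ccc(C)cc2)c(C)c1[C@@H]3Cn1cc(-c2ccc(Br)cc2)nn1` stops at the limit of the assay, > 20000 nM. Compound 2 `C=C1C[C@]23C[C@@]1(O)CC[C@@H]2c1cccc(C)c1[C@@H]3Cn1cc(-c2ccc(C)cc2)nn1` likewise stops at the limit, giving > 20000 nM. Compound 3 `COc1ccc(-c2cn(C[C@H]3c4c(ccc(O)c4C)[C@@H]4CC[C@@]5(C)C[C@]43CC5=O)nn2)cc1` is the starting point for the step that follows, and in this assay compound 3 also returns only the limit, > 20000 nM. Compound 3 therefore stands nowhere in particular among the three: it shares (the limit of > 20000 nM in this assay, at which 3 of the 3 values shown sit), and no order among the compounds can be read from that.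

Compound 4 `Cc1c(O)ccc2c1[C@H](Cn1cc(-c3ccccc3)nn1)[C@@]13CC(=O)[C@@](C)(CC[C@@H]21)C3` differs from compound 3 in a single place: hydrogen in place of methoxy on an aromatic carbon. Cut one bond further out, the same difference reads 4-methoxyphenyl to phenyl. Among the measured compounds shown here, no measured pair among the three compounds differs in only one place, so there is no measured step to show how a change of this kind moves the read-out. What remains is that compound 3 sits at the limit and that the change is small. The step from compound 3 to compound 4 is expected to be a step that the limit leaves unreadable from compound 3 to compound 4, that is, nothing beyond the scatter, and most likely the assay will again report only a limit. Compound 4 is expected to give roughly 30000 nM, within a range from 10000 nM to 100000 nM.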

Compound 4, half-maximal inhibitory concentration: > 20000 nM
Compound 4: no number, only a limit (the forecaster's own chance of this, stated with the estimate: 80%); the middle value lies beyond the limit too.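

No size can be read for the change between compound 3 and compound 4, because both give only a limit of the assay and not a number: the limit of > 20000 nM in this assay, at which 4 of the 4 values shown sit.

The compounds shown leave open whether any compound on this shared core gives a real number in this assay, and how a change such as 4-methoxyphenyl to phenyl moves that number.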